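The compounds below may be only part of what the source reports. "The series", "measured", "known", "first", "only" and "open" are said of these compounds alone.

Compound 1, `O=C1OC[C@H](Cc2ccccc2)[C@H]1Cc1cccc(OC(F)(F)F)c1`, was tested in a functional assay on HL-60 cells (Homo sapiens) for cytotoxicity, read by WST assay, with a stated time of 48 h (on this read-out lower numbers stand for an effect already at smaller amounts and higher numbers for an effect only at larger amounts of compound), where compound 1 gives 34000 nM. Compound 2, `COCOc1cccc(C[C@H]2C(=O)OC[C@@H]2Cc2ccccc2)c1`, differs from compound 1 only by the change (methoxymethyl in place of trifluoromethyl on an oxygen on an aromatic ring), and in this assay compound 2 gives 80000 nM. That single change made the step of a 2.4-fold higher number from compound 1 to compound 2 (0.37 log units; beyond the scatter).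

Compound 3, `O=C1OC[C@H](Cc2ccccc2)[C@H]1Cc1ccc(OC(F)(F)F)cc1`, is built from the same atoms as compound 1 but joined differently; how the two cores differ is not broken down here. In this assay compound 3 gives 27000 nM, and its values against compound 1 lie within the scatter of each other, so nothing separates them.

Compound 4, `COCOc1ccc(C[C@H]2C(=O)OC[C@@H]2Cc2ccccc2)cc1`, is not yet measured. It differs from compound 3 by the change (methoxymethyl in place of trifluoromethyl on an oxygen on an aromatic ring), the same change as from compound 1 to compound 2, at a place described in the same words. Within the data shown here, since the only measured instance of this change gave the step of a 2.4-fold higher number from compound 1 to compound 2 (0.37 log units; beyond the scatter), a step of similar size is expected from compound 3 to compound 4, namely a 2.4-fold higher number from compound 3 to compound 4 (0.38 log units; beyond the scatter). On that basis compound 4 is estimated to give 65000 nM, with a range from 35000 nM to 120000 nM.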

Compound 4, half-maximal effective concentration: 71000 nM
For compound 4 the middle estimate is 1.1-fold (0.04 log units) below the measured one; low and high end bracket the measured number.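

Replacing trifluoromethoxy with methoxymethoxy a second time, now on a different core, gave a 2.6-fold higher number from compound 3 to compound 4 (0.42 log units; beyond the scatter) in this assay. Placed side by side, the two results agree in direction and do not separate in size: the same change on two cores in this assay, a 2.4-fold higher number (0.37 log units; beyond the scatter) from compound 1 to compound 2 and a 2.6-fold higher number (0.42 log units; beyond the scatter) from compound 3 to compound 4, 1.1-fold (0.05 log units) apart, within the scatter of two such steps. So, for these two cores, the change carries over, and the effect seen on one core would have been a fair guide to the other, but two pairs of compounds in a single assay cannot establish a general rule for the series or explain why the number rises.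

The compounds shown leave open whether a step of this size would also appear on a third core, or in a different assay. They also leave open what would happen with other groups at this place, such as a plain methyl or a longer chain on the oxygen, or an amine or a carboxylic acid in place of the whole trifluoromethoxy group.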